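Methoxymethyl amide in a fluoropyrimidine antiproliferative series

The compounds below may be only part of what the source reports. "The series", "measured", "known", "first", "only" and "open" are said of these compounds alone.

Compound 1 `CN(C)CC(=O)Nc1cccc(Nc2ncc(F)c(Nc3ccc(F)cc3)n2)c1` gives 1180 nM in a functional assay on A549 cells (Homo sapiens) for antiproliferative activity, read by sulforhodamine B assay, with a stated time of 3 days; a higher number here means a weaker inhibitor of growth, a lower number a stronger inhibitor of growth. Compound 2 `O=C(Nc1cccc(Nc2ncc(F)c(Nc3ccc(F)cc3)n2)c1)c1ccccc1` gives 37800 nM in this assay. Compound 3 `O=C(Nc1cccc(Nc2ncc(F)c(Nc3ccc(F)cc3)n2)c1)c1cnccn1` gives 10300 nM in this assay.

Compound 3 stands second highest of the three numbers, nearest compound 2 (a 3.7-fold lower number from compound 2 to compound 3 (0.56 log units; beyond the scatter)) and furthest from compound 1 (an 8.7-fold higher number from compound 1 to compound 3 (0.94 log units; beyond the scatter)). The next compound, compound 4 `COCC(=O)Nc1cccc(Nc2ncc(F)c(Nc3ccc(F)cc3)n2)c1`, keeps the shared core and alters only the amide substituent: methoxymethyl in place of pyrazin-2-yl on a carbonyl carbon. Going by the values given here, two measured steps bear on this. Compound 1, carrying a short chain on the carbonyl carbon, was the strongest of the three, and replacing that chain with either aromatic ring raised the number (a 32-fold higher number from compound 1 to compound 2 (1.51 log units; beyond the scatter), an 8.7-fold higher number from compound 1 to compound 3 (0.94 log units; beyond the scatter)). Compound 4 returns to a short chain, though not the same one as in compound 1, so a move back toward the number of compound 1 is expected, without any certainty that it is reached. The step is therefore expected to be a 2.9-fold lower number from compound 3 to compound 4 (0.47 log units; beyond the scatter), a modest lowering beyond the scatter. Compound 4 is estimated at 3500 nM, with a range from 1200 nM to 10000 nM.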

Compound 4, concentration for 50% growth inhibition: 2050 nM
Estimate against measurement, compound 4: 1.7-fold (0.23 log units) above, within the range that was stated.
By their numbers in this assay, from the lowest: compounds 1 and 4 (each within the scatter of the next); then compound 3; then compound 2.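

Swapping the pyrazin-2-yl ring for methoxymethyl on the carbonyl carbon gives a 5.0-fold lower number from compound 3 to compound 4 (0.70 log units; beyond the scatter) in this assay and, set against the phenyl amide, the same chain gives an 18-fold lower number from compound 2 to compound 4 (1.27 log units; beyond the scatter) in the same assay. Until now only one amide carried a chain, so its lead over the aromatic rings could have belonged to the dimethylamino group alone; methoxymethyl shows that a chain without that amine also stands clear of both rings. Methoxy in place of dimethylamino on the saturated chain carbon gives a 1.7-fold higher number from compound 1 to compound 4 (0.24 log units; within the scatter) and this step is too small to count as a change, so at this position the dimethylamino group is not needed to reach this level of growth inhibition.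

On these data alone, whether a plain methyl, a longer chain such as methoxyethyl, or a morpholine or carboxylic acid at the end of the chain would hold this level remains open. As far as these compounds go, all four compounds share one core and one cell line, so it is also open whether the lead of the chains over the rings extends to other cores or other cells.

Nothing among the data offered here accounts for the difference between chains and rings at this position.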